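Lengthening the decyl tail of compound 3 by three carbons

This account rests on a few compounds, and the source may have more. Where it says the series, first, only, none or still open, it means among the compounds named here.

Compound 3, `CCCCCCCCCCc1ccc(CCC(N)(CO)CO)cc1`, gives 0.1 mg/kg in a functional assay on the whole organism with Rattus norvegicus as the target (a lower number here means that less compound is needed, a higher number that more compound is needed for the effect), the lowest of the two numbers recorded so far. Its nearest neighbour is compound 1, `CCCCCCCCCCc1ccc(C(N)(CO)CO)cc1`, which gives 0.3 mg/kg; the step of a 3.0-fold lower number from compound 1 to compound 3 (0.48 log units; beyond the scatter) is modest but beyond the scatter. Compound 2, `CCCCCCc1ccc(CCCCC(N)(CO)CO)cc1`, gives > 3 mg/kg, which is a limit of the assay and not a number, (the limit of > 3 mg/kg in this assay, at which 1 of the 3 values shown sits). For the measured compounds named here, compound 2 carries a shorter hexyl tail and a longer linker than compound 3, so it differs in two places and no single step connects the two.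

The next compound is compound 4, `CCCCCCCCCCCCCc1ccc(CCC(N)(CO)CO)cc1`, which differs from compound 3 by propyl in place of hydrogen on a saturated chain carbon, ten or more bonds along the chain from an aromatic carbon. Going by the values given here, no measured step changes the tail on this side of the shared core: the step from compound 1 to compound 3 moved the aminodiol head, not the chain. Among the compounds with values here, there is therefore no direct precedent for how a longer tail acts here, and no step beyond the scatter is expected in this assay. Compound 4 is estimated at 0.1 mg/kg, within a range from 0.03 mg/kg to 0.4 mg/kg, which means an expected step of no change at the digits printed from compound 3 to compound 4 (within the scatter).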

Compound 4, dose for 50% inhibition: 0.03 mg/kg
The estimate for compound 4 lay 3.3-fold (0.52 log units) above the measured number; the measured number falls inside the stated range.
By their numbers in this assay, from the lowest: compound 4; then compound 3; then compound 1. At a limit, above all of these: compound 2.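

In this assay the step is a 3.3-fold lower number from compound 3 to compound 4 (0.52 log units; beyond the scatter) and it is the first one shown that changes the tail and not the aminodiol head. The decyl tail of compound 3 is therefore not the end of what this position accepts: propyl added far out on the chain, with no ring, no hydrogen-bond donor or acceptor and no net charge, still lowers the dose needed, and this modest gain is matched in grade by a 3.0-fold lower number from compound 1 to compound 3 (0.48 log units; beyond the scatter) on the head side. Nothing among the data shown bears on why the longer tail gives this result.

A single step cannot show whether the number keeps falling as the tail grows, and a still longer chain could continue the fall, level off or reverse it. Nor is it open to reading whether chain length alone counts, which a tail of the same length ending in an amine or a carboxylic acid would begin to test.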